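Ring-position change of an iodobenzyl substituent

A few compounds are considered here, and "the series" means these few. Any claim that something is new, unique, unknown or untested is made for them only; others in the source may bear on it.

Compound 3 `O=c1cc(CNCc2cccc(I)c2)oc2ccc(O)c(O)c12` is one of three measured members of this series. In an ADME assay on Huh-7 cells (Homo sapiens) for cytotoxicity (on this read-out lower numbers stand for higher toxicity in this test and higher numbers for lower toxicity in this test), compound 3 gives > 100000 nM, which is a limit of the assay and not a number. Compound 1 `O=c1cc(CNCc2ccccc2Cl)oc2ccc(O)c(O)c12` likewise gives > 100000 nM in this assay, again a limit rather than a number. Going by the values given here, compound 2 `O=c1cc(CNCc2ccccc2I)oc2ccc(O)c(O)c12` gives 87300 nM in this assay, the only plain number so far. Both an at least 1.1-fold lower number from compound 1 to compound 2 (0.05 log units; that floor lies within the scatter) and an at least 1.1-fold higher number from compound 2 to compound 3 (0.05 log units; that floor lies within the scatter) carry floors that fall within the scatter, so neither reads as a real change. The step that the two limits leave unreadable from compound 1 to compound 3 cannot be sized because both values sit at the limit of > 100000 nM in this assay, at which 2 of the 3 values shown sit.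

Compound 4 `O=c1cc(CNCc2ccc(I)cc2)oc2ccc(O)c(O)c12` has not yet been measured. It differs from compound 3 by 4-iodophenyl in place of 3-iodophenyl on a saturated chain carbon bound to an amine nitrogen. Among the compounds with values here, no measured step makes exactly this move; the nearest comparison is an at least 1.1-fold higher number from compound 2 to compound 3 (0.05 log units; that floor lies within the scatter), which also shifts the iodophenyl group to another ring position and stays within the scatter. A step in this assay beyond the scatter is therefore not expected; compound 4 is expected to sit at or near the limit as compound 3 does. Compound 4 is estimated at 100000 nM in this assay, with a range from 60000 nM to 200000 nM. This estimate corresponds to an expected step of a number no higher from compound 3 to compound 4 (the limit leaves the size open).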

Compound 4, half-maximal cytotoxic concentration: 41700 nM
Beside the measured number, compound 4's estimate is 2.4-fold (0.38 log units) above it; the measured number lies below the stated range.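

In this assay, 4-iodophenyl in place of 3-iodophenyl gives an at least 2.3-fold lower number from compound 3 to compound 4 (0.37 log units; beyond the scatter), and 4-iodophenyl in place of 2-iodophenyl gives a 2.1-fold lower number from compound 2 to compound 4 (0.32 log units; beyond the scatter), so at this place on the saturated chain carbon bound to an amine nitrogen, the choice of iodophenyl isomer now produces a difference beyond the scatter, which the step between compound 2 and compound 3 did not. With 4-iodophenyl in place of 2-chlorophenyl, the series shows an at least 2.3-fold lower number from compound 1 to compound 4 (0.37 log units; beyond the scatter), which leaves compound 4 with the lowest number of the four and thus the highest toxicity in this test. Two of the three new steps give only a floor on their size, because their starting values are limits of the assay: the limit of > 100000 nM in this assay, at which 2 of the 4 values shown sit.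

On these data alone, it remains open whether a 4-chlorophenyl or a 4-methoxyphenyl group at this place would give a similarly low number, so the shift cannot yet be tied to iodine or to the 4-substituted ring alone. The step from compound 1 to compound 3 cannot be read, and the series gives no view of whether a longer chain between the amine and the ring would keep the difference.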